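This account rests on a few compounds, and the source may have more. Where it says the series, first, only, none or still open, it means among the compounds named here.

In a functional assay on HOS-TE85 cells (Homo sapiens) for inhibition, read by CCK-8 assay, with a stated time of 72 h (on this read-out higher numbers stand for weaker inhibition and lower numbers for stronger inhibition), the measured compounds stand as follows:

Compound 1 `COc1ccc(F)cc1N1C(=O)CSC1c1cccc(C(=O)NCCCCn2cccn2)c1` gives 97.3 nM in this series
Compound 2 `O=C(NCCCCc1ccccc1)c1cc(F)cc(C2SCC(=O)N2c2ccccn2)c1` gives 14.2 nM in this series
Compound 3 `COc1ccc(F)cc1N1C(=O)CSC1c1cccc(C(=O)NCCCCc2ccccc2)c1` gives 8.8 nM in this series

Compound 1 carries the highest number of the three, and compound 2 and compound 3 both lie beyond the scatter from it. Compound 4 `COc1ccccc1N1C(=O)CSC1c1cccc(C(=O)NCCCCn2cccn2)c1` has not yet been measured. It departs from compound 1 by a single change, hydrogen in place of fluoro on an aromatic carbon which puts hydrogen in place of fluoro on an aromatic carbon, so that 5-fluoro-2-methoxyphenyl becomes 2-methoxyphenyl.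

Within the data shown here, the one measured step between close neighbours is an 11-fold lower number from compound 1 to compound 3 (1.04 log units; beyond the scatter) and it is large, but it concerns phenyl in place of 1H-pyrazol-1-yl and leaves the 5-fluoro-2-methoxyphenyl group untouched. Compound 2 differs from compound 1 in more than one place. Among the measured compounds shown here, no measured pair therefore isolates the loss of this fluoro, and the data argue for no direction. In this assay no step beyond the scatter is expected, so the estimate starts from compound 1 (97.3 nM) with a wide margin. The expected step is a 1.0-fold higher number from compound 1 to compound 4 (0.01 log units; within the scatter) and remains an estimate. For compound 4 the estimate is 100 nM and the expected range runs from 40 nM to 250 nM on repeated measurement.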

Compound 4, half-maximal inhibitory concentration: 91.7 nM
Beside the measured number, compound 4's estimate is 1.1-fold (0.04 log units) above it; measured number inside the range.
By their numbers in this assay, from the lowest: compounds 3 and 2 (each within the scatter of the next); then compounds 4 and 1 (each within the scatter of the next).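

In this assay, hydrogen in place of fluoro on the aromatic carbon para to the methoxy group gives a 1.1-fold lower number from compound 1 to compound 4 (0.03 log units; within the scatter), so compound 1 and compound 4 cannot be told apart at this position. Among these compounds, this is the first pair that isolates the fluoro, and with the 1H-pyrazol-1-yl chain held fixed, the 5-fluoro-2-methoxyphenyl and 2-methoxyphenyl groups read alike, whereas the chain exchange gives an 11-fold lower number from compound 1 to compound 3 (1.04 log units; beyond the scatter) and lies beyond the scatter. No measured evidence bears on why the fluoro exchange reads this way.

On these data alone, it remains open whether the same exchange would read alike on the phenyl-bearing chain of compound 3, since the fluoro has been isolated here only with the 1H-pyrazol-1-yl chain in place. Also open, as far as these compounds go, is how chloro, trifluoromethyl or a nitrile on this aromatic carbon would read, and whether a hydroxyl group in place of the methoxy group would leave the number within the scatter as well.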